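One Stereocentre Inverted on the Hydroxy-Dimethylcyclobutyl Group

The source may report more compounds than this note shows. Statements on the series, on what has been measured and on what is new or still open speak of the compounds shown alone.

Compound 3 `CC1(C)[C@H](O)C[C@@H]1Nc1nc(NCc2cnccc2C(F)(F)F)ncc1C#N` gives 8500 nM in an assay on isolated protein for inhibition of protein kinase C delta type (Homo sapiens), read by TR-FRET, with a stated time of 2 h (a higher number here means a weaker inhibitor, a lower number a stronger inhibitor), the highest of the three numbers recorded. Compound 1 `CC1(C)C[C@H](Nc2nc(NCc3cnccc3C(F)(F)F)ncc2C#N)CC[C@@H]1O`, carrying a 4-hydroxy-3,3-dimethylcyclohexyl group on a nitrogen on an aromatic ring, gives 800 nM in this assay. Carrying the same 3-hydroxy-2,2-dimethylcyclobutyl group as compound 3, compound 2 `CC1(C)[C@@H](O)C[C@H]1Nc1nc(NCc2cnccc2C(F)(F)F)ncc1C#N` gives 600 nM. The ring change shows a 1.3-fold lower number from compound 1 to compound 2 (0.12 log units; within the scatter), whereas an 11-fold higher number from compound 1 to compound 3 (1.03 log units; beyond the scatter) and a 14-fold higher number from compound 2 to compound 3 (1.15 log units; beyond the scatter). Compound 3 is therefore the weakest inhibitor of the three.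

Compound 4 `CC1(C)[C@@H](Nc2nc(NCc3cnccc3C(F)(F)F)ncc2C#N)C[C@@H]1O` differs from compound 3 only in configuration: the two compounds have the same atoms and bonds and differ only in configuration as drawn: 1 of 2 stereo elements differ; a stereocentre at a saturated ring carbon is drawn R in compound 3 and S in compound 4. The step that bears on it is the inversion of both centres, where a 14-fold higher number from compound 2 to compound 3 (1.15 log units; beyond the scatter), a difference that arises because of the fact that compounds 2 and 3 differ only in the configuration as drawn. Compound 4 shares one centre with compound 2 and the other with compound 3. The step is therefore expected to be a move toward lower numbers smaller than the full swing between the mirror images, estimated as a 3.4-fold lower number from compound 3 to compound 4 (0.53 log units; beyond the scatter). Compound 4 is thus estimated at 2500 nM, with a range from 600 nM to 9000 nM.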

Compound 4, half-maximal inhibitory concentration: 2000 nM
Beside the measured number, compound 4's estimate is 1.3-fold (0.10 log units) above it; measured number inside the range.
By their numbers in this assay, from the lowest: compounds 2 and 1 (each within the scatter of the next); then compound 4; then compound 3.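

Compound 4 separates the two stereocentres that are inverted together between the mirror images, and in this assay one inversion gives a 4.3-fold lower number from compound 3 to compound 4 (0.63 log units; beyond the scatter), while inversion of the other centre gives a 3.3-fold higher number from compound 2 to compound 4 (0.52 log units; beyond the scatter). Both steps lie beyond the scatter, so each centre counts on its own, and neither carries the whole swing, the pairs differing in nothing else: the fact that compounds 2 and 4 differ only in the configuration as drawn and the fact that compounds 3 and 4 differ only in the configuration as drawn Set against the 4-hydroxy-3,3-dimethylcyclohexyl group of compound 1, this isomer gives a 2.5-fold higher number from compound 1 to compound 4 (0.40 log units; beyond the scatter), so how the 3-hydroxy-2,2-dimethylcyclobutyl group compares with that ring depends on its configuration.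

Still open, on these data alone, is whether the 4-hydroxy-3,3-dimethylcyclohexyl group responds in the same way to inversion of its own centres. Also open, as far as these compounds go, is whether this order of configurations would hold with an amine in place of the hydroxy group.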